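Replacing a cyclopropylsulfonyl cap with a trifluoromethyl carbonyl

This account rests on a few compounds, and the source may have more. Where it says the series, first, only, none or still open, it means among the compounds named here.

Measured so far:
Compound 1 `O=S(=O)(Nc1cccc2c1CCCC2c1c[nH]cn1)C1CC1` gives < 10000 nM in an assay on isolated protein (Cricetulus griseus) for binding affinity to Alpha-1B adrenergic receptor (Mesocricetus auratus), read by radioligand binding (a lower number here means a stronger inhibitor, a higher number a weaker inhibitor), which is a limit of the measurement rather than a number.
Compound 2 `CC(c1cccc(NS(C)(=O)=O)c1)c1c[nH]cn1` gives < 10000 nM in this assay, likewise a limit.
Compound 3 `CCS(=O)(=O)Nc1cccc2c1SCCC2c1c[nH]cn1` gives < 10000 nM in this assay, again a limit.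

Among the compounds with values here, compound 1 therefore has no exact number of its own to stand on: it sits at the same limit as the two other measured compounds (the limit of < 10000 nM in this assay, at which 3 of the 3 values shown sit), so none of the three can be ranked against the others, and no step between them can be sized.

Compound 4 `O=C(Nc1cccc2c1CCCC2c1c[nH]cn1)C(F)(F)F` keeps the core of compound 1 and changes only its cap ((trifluoromethyl)carbonyl in place of cyclopropylsulfonyl on a nitrogen on an aromatic ring). Within the data shown here, with no measured step to lean on, the expected step from compound 1 to compound 4 a step that the limit leaves unreadable from compound 1 to compound 4 is small, in no firm direction, and likely within the scatter; the most probable outcome is that compound 4 also returns only a limit. Compound 4 is estimated at 3000 nM, expected to fall between 300 nM and 10000 nM.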

Compound 4, inhibition constant: < 10000 nM
Compound 4 ended at the assay's limit; the forecaster's own chance of this, stated with the estimate: 70%; the middle value lies beyond the limit too.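

Within the data shown here, compound 1 and compound 4 both end at a limit rather than a number, so no step between them can be read: the limit of < 10000 nM in this assay, at which 4 of the 4 values shown sit. The compounds shown leave open how strong any of them truly is in this assay and whether changing the cap shifts that strength at all.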